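Cytotoxicity of a defined stereoisomer of compound 2

The compounds below may be only part of what the source reports. "The series", "measured", "known", "first", "only" and "open" are said of these compounds alone.

Compound 1, `CN(Cc1nc2ccccc2n1CC1CCNC1)C1CCCc2cccnc21`: 7700 nM
Compound 2, `CN1CCCC(Cn2c(CN(C)C3CCCc4cccnc43)nc3ccccc32)C1`: 3000 nM
Compound 3, `CN1CCC(Cn2c(CN(C)C3CCCc4cccnc43)nc3ccccc32)C1`: 15000 nM

In an ADME assay on HOS cells (Homo sapiens) for cytotoxicity (on this read-out lower numbers stand for higher toxicity in this test and higher numbers for lower toxicity in this test), compound 2 gives the lowest of the three numbers. The nearest measured compound is compound 1, and the step of a 2.6-fold lower number from compound 1 to compound 2 (0.41 log units; beyond the scatter) lies beyond the scatter; the furthest is compound 3, and the step of a 5.0-fold higher number from compound 2 to compound 3 (0.70 log units; beyond the scatter) also lies beyond the scatter. The step of a 1.9-fold higher number from compound 1 to compound 3 (0.29 log units; within the scatter) lies within the scatter.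

Compound 4, `CN1CCC[C@@H](Cn2c(CN(C)[C@H]3CCCc4cccnc43)nc3ccccc32)C1`, is now to be measured in this assay. Its relation to compound 2 is the following: the two compounds have the same atoms and bonds; at least one stereo element is drawn with a configuration in one of them and without one in the other: 2 of 2 stereo elements differ; a stereocentre at a saturated ring carbon is drawn without a configuration in compound 2 and R in compound 4; a stereocentre at a saturated ring carbon is drawn without a configuration in compound 2 and S in compound 4. No atom leaves and none enters; compound 4 is a single defined stereoisomer of the material drawn without configurations as compound 2.

None of the three measured steps concerns a stereo element: the steps from compound 1 to compound 2 and from compound 2 to compound 3 exchange ring sizes on the saturated chain carbon, and the step from compound 1 to compound 3 adds a methyl on an amine nitrogen in a ring. The data therefore give no direct guide to this change. The expected step, no change at the digits printed from compound 2 to compound 4 (within the scatter), is none beyond the scatter, with a wide range to allow for a difference between stereoisomers. The estimate for compound 4 in this assay is 3000 nM, between 1000 nM and 9000 nM.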

Compound 4, half-maximal cytotoxic concentration: 3500 nM
Compound 4: middle estimate off by 1.2-fold (0.07 log units), on the low side, and the stated range covers the measured number.
By their numbers in this assay, from the lowest: compounds 2 and 4 (each within the scatter of the next); then compounds 1 and 3 (each within the scatter of the next).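

In this assay, for the compounds shown here, the earlier compounds spoke only to ring size on the saturated chain carbon and to a methyl on an amine nitrogen in a ring, and none of their steps touched a stereo element. Drawing both stereocentres, one as R and one as S, gives a 1.2-fold higher number from compound 2 to compound 4 (0.07 log units; within the scatter) and so provides the first reading on configuration in this series, with the single stereoisomer compound 4 staying within the scatter of compound 2. The comparison shows that this one defined form keeps the cytotoxicity number of the material drawn without configurations, but what it can say about configuration as such is limited by the way the two compounds are drawn: the fact that one of compounds 2 and 4 is drawn with a defined configuration and the other without, at the place where they differ.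

As far as these compounds go, how the other stereoisomers of this structure compare with compound 4 remains open, so no effect of either stereocentre can be assigned on its own. Also open, from the compounds shown here alone, is whether an ethyl group in place of the methyl on the ring nitrogen of the 1-methylpiperidin-3-yl group would leave the number unchanged in this defined stereoisomer.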